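The compounds below may be only part of what the source reports. "The series", "measured", "known", "first", "only" and "open" are said of these compounds alone.

Measured compounds:
- compound 1, `CCN(CC)CCN1N=C(c2ccc(Br)cc2)CC2=C1CC(C)(C)CC2=O`: 100 mg/kg in a functional assay on the whole organism (strain CF) with Mus musculus as the target; a higher number here means that more compound is needed for the effect, a lower number that less compound is needed
- compound 2, `CN(C)CCN/N=C1/CC(C)(C)CC2=C1CC(c1ccccc1)=NN2CCN(C)C`: "not active" (no number reported) in this assay
- compound 3, `CC1(C)CC(=O)C(CC(=O)c2ccccc2)=C(NNC(=N)N)C1`: "not active" (no number reported) in this assay

Of the three measured compounds only compound 1 gives a number in this assay, 100 mg/kg. Compound 2 is reported as "not active" (no number reported), and compound 3 likewise as "not active" (no number reported), so compound 3 stands without a single number, and one further compound shares that position. Within the data shown here, no step between measured compounds that differ in a single place is available, so nothing can be said about the size of any step among them.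

Compound 4, `CC1(C)CC(=O)C(CC(=O)c2ccccc2)=C(NNC(=O)c2ccncc2)C1`, has not yet been measured in this assay. It differs from compound 3 in one place: a group of 8 heavy atoms (6 carbon, 1 nitrogen, 1 oxygen; one six-membered aromatic ring with 1 hetero atom) in place of a group of 3 heavy atoms (1 carbon, 2 nitrogen; no ring), on an amine nitrogen. Among the measured compounds shown here, since compound 3 shows no activity, there is no numerical anchor for this step, and the expected direction rests only on the fact that compound 1, the one compound with a number, gives 100 mg/kg. A step of any size beyond the scatter cannot be foreseen from the data. Compound 4 is therefore expected to give about 200 mg/kg in this assay, within a range of 50 mg/kg to 1000 mg/kg, with a substantial chance that again no number is reported.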

Compound 4, dose for half-maximal effect: "not active" (no number reported)
For compound 4 the study gives words and no number; there is nothing to compare the estimate with.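

Among these compounds, compound 3 and compound 4 are both reported as not active in this assay and neither has a number, so no step between them can be read. No measured evidence bears on this result. The compounds shown leave open whether any group on this amine nitrogen would give a measurable effect.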